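A few compounds are considered here, and "the series" means these few. Any claim that something is new, unique, unknown or untested is made for them only; others in the source may bear on it.

In a functional assay on CHO-K1 cells for antagonist activity at C-X-C chemokine receptor type 3 (Homo sapiens), read by FLIPR, with a stated time of 10 min (on this read-out lower numbers stand for stronger inhibition and higher numbers for weaker inhibition), compound 2 `CCOc1ncc(-c2nc(C(F)(F)F)sc2N2CCN(C(=O)Cn3ccc4cccnc43)[C@H](C)C2)cn1` gives 3.8 nM, while compound 1 `CCCc1ncc(-c2nc(C(F)(F)F)sc2N2CCN(C(=O)Cn3cnc4cccnc43)[C@H](C)C2)cn1` gives 3.3 nM; the two numbers lie within the usual scatter of each other, so neither can be called stronger. Compound 3 `CCOc1ncc(-c2nc(C(F)(F)F)sc2N2CCN(C(=O)Cn3nc(C)cc3C)[C@H](C)C2)cn1` differs from compound 2 by a group of 7 heavy atoms (5 carbon, 2 nitrogen; one five-membered aromatic ring with 2 hetero atoms) in place of a group of 9 heavy atoms (7 carbon, 2 nitrogen; one five-membered aromatic ring with 1 hetero atom, one six-membered aromatic ring with 1 hetero atom), on a saturated chain carbon bound to a carbonyl carbon. Within the data shown here, no measured pair shows the effect of such a change here, so the expectation rests on the size of the swap alone: a modest rise in the number is expected, that is, a step from compound 2 to compound 3 of about a 2.6-fold higher number from compound 2 to compound 3 (0.42 log units; beyond the scatter). Compound 3 is therefore estimated at 10 nM, with a range from 3 nM to 40 nM.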

Compound 3, half-maximal inhibitory concentration: 2.3 nM
Estimate against measurement, compound 3: 4.3-fold (0.64 log units) above, outside the stated range (below it).
By their numbers in this assay, from the lowest: compounds 3, 1 and 2 (each within the scatter of the next).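

On the saturated chain carbon bound to a carbonyl carbon, the two-ring group of compound 2 gives way to the single-ring 3,5-dimethyl-1H-pyrazol-1-yl with a 1.7-fold lower number from compound 2 to compound 3 (0.22 log units; within the scatter) and no real difference in this assay. For this pair, then, the second ring of the leaving group is not needed to keep the number at this level. Nothing measured here explains why the two groups read alike. Still open, from the compounds shown here alone, is whether the two methyl groups matter, and what an unsubstituted pyrazol-1-yl or a simple amine on that carbon would give.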